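The compounds below may be only part of what the source reports. "The series", "measured", "known", "first", "only" and "open" are said of these compounds alone.

Notes on the series. The shared core is that of compound 1 `CC#C[C@@H](CC(=O)O)c1ccc(OC[C@H]2COc3ccc(C)cc3O2)cc1`, which in a functional assay on HEK293 cells for agonist activity at Free fatty acid receptor 1 (Homo sapiens), read by fluorescence and calcium flux, with a stated time of 10 min (on this read-out lower numbers stand for an effect already at smaller amounts and higher numbers for an effect only at larger amounts of compound), gives 120 nM. Compound 2 `CC#C[C@@H](CC(=O)O)c1ccc(OC[C@H]2COc3ccc(OC(F)(F)F)cc3O2)cc1` gives 700 nM in this assay, and compound 3 `CC#C[C@@H](CC(=O)O)c1ccc(OC[C@H]2COc3ccc(S(C)(=O)=O)cc3O2)cc1` gives 27200 nM, the highest of the three numbers recorded. Both steps into compound 3 are large and beyond the scatter: a 230-fold higher number from compound 1 to compound 3 (2.36 log units; beyond the scatter) and a 39-fold higher number from compound 2 to compound 3 (1.59 log units; beyond the scatter). The step between the two lower numbers, a 5.8-fold higher number from compound 1 to compound 2 (0.77 log units; beyond the scatter), is modest by comparison.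

Compound 4 `CC#C[C@@H](CC(=O)O)c1ccc(OC[C@H]2COc3ccc(C(=O)N4CCOCC4)cc3O2)cc1` is the next step from compound 3: (morpholin-4-yl)carbonyl in place of methylsulfonyl on an aromatic carbon. Going by the values given here, no measured compound carries a (morpholin-4-yl)carbonyl group at this place, so the change has no direct precedent. What the measured steps do show is that the methylsulfonyl group of compound 3 sits at the weak end of everything recorded. Compound 4 is therefore expected to move back down in this assay, though only part of the way, with an estimated 6000 nM (range 1500 nM to 30000 nM). The expected step from compound 3 is a 4.5-fold lower number from compound 3 to compound 4 (0.66 log units; beyond the scatter).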

Compound 4, half-maximal effective concentration: > 50000 nM
Compound 4 ended at the assay's limit (the forecaster's own chance of this, stated with the estimate: 10%); at least 8.3-fold (0.92 log units) between middle value and limit.
By their numbers in this assay, from the lowest: compound 1; then compound 2; then compound 3. At a limit, above all of these: compound 4.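

Compound 4 stands at a limit of the assay, not at a number: the limit of > 50000 nM in this assay, at which 1 of the 4 values shown sits. Going by these compounds alone, the steps of an at least 71-fold higher number from compound 2 to compound 4 (1.85 log units; beyond the scatter) and an at least 410-fold higher number from compound 1 to compound 4 (2.61 log units; beyond the scatter) are both large, so at this aromatic carbon methylsulfonyl is not the only group far up the scale: (morpholin-4-yl)carbonyl, with its six-membered non-aromatic ring, stands there too. Against methylsulfonyl only a floor can be read (an at least 1.8-fold higher number from compound 3 to compound 4 (0.26 log units; that floor lies within the scatter)), and it gives no order between these two groups.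

As far as these compounds go, how far compound 4 really lies from compound 3 stays open. From the compounds shown here alone, it is also open whether the step goes with the carbonyl or with the ring, and how a dimethylaminocarbonyl group, a simple amine or a methoxy group would read at this place.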